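The source may report more compounds than this note shows. Statements on the series, on what has been measured and on what is new or still open speak of the compounds shown alone.

Compound 2 `Cc1ccc2[nH]c(C(=O)N[C@H]3CN(S(=O)(=O)c4ccccc4)C[C@@H]3C(=O)NC[C@H]3CCCN3C)cc2c1` was tested in an ADME assay on cells (Hepatocyte, Rattus norvegicus) for metabolic stability (a higher number here means faster removal of the compound, a lower number slower removal), where compound 2 gives 21 uL/min. Of the two numbers shown it is the one that stands on top, but only by a margin that the scatter covers: compound 1 `Cc1ccc2[nH]c(C(=O)N[C@H]3CN(S(=O)(=O)c4ccccc4)C[C@@H]3C(=O)NCCN(C)C)cc2c1` gives 16 uL/min in this assay, and the step of a 1.3-fold higher number from compound 1 to compound 2 (0.12 log units; within the scatter) does not exceed the usual variation between repeats. Compound 3 `Cc1ccc2[nH]c(C(=O)N[C@H]3CN(S(=O)(=O)c4ccccc4)C[C@@H]3C(=O)N[C@H]3CCCN(C)C3)cc2c1` is a rearrangement of compound 2, with 1-methylpiperidin-3-yl in place of (1-methylpyrrolidin-2-yl)methyl on an amide-type nitrogen. Among the compounds with values here, the one measured step that bears on this change is a 1.3-fold higher number from compound 1 to compound 2 (0.12 log units; within the scatter), since it too exchanged the group on the amide-type nitrogen for another containing a single basic-type ring nitrogen, and it produced nothing beyond the scatter. Compound 3 therefore is expected to show a step of about a 1.0-fold higher number from compound 2 to compound 3 (0.02 log units; within the scatter) in this assay, that is, no movement that can be told from noise. On that basis, compound 3 is estimated to give 22 uL/min in this assay, with a range from 11 uL/min to 44 uL/min that reflects the scatter of the method rather than any directional expectation.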

Compound 3, intrinsic clearance in a liver preparation (reported as CLH), per the amount of preparation that the assay uses: 23 uL/min
Compound 3: the middle estimate sits 1.0-fold (0.02 log units) below what was measured; the range from low to high includes it.
By their numbers in this assay, from the lowest: compounds 1, 2 and 3 (each within the scatter of the next).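

Within the data shown here, exchanging (1-methylpyrrolidin-2-yl)methyl for 1-methylpiperidin-3-yl on an amide-type nitrogen gives a 1.1-fold higher number from compound 2 to compound 3 (0.04 log units; within the scatter) in this assay, so replacing a five-membered with a six-membered non-aromatic ring, with the same atoms joined differently, produces no step that can be told from noise. The comparison with the chain-bearing compound gives a 1.4-fold higher number from compound 1 to compound 3 (0.16 log units; within the scatter) in the same assay, which means that 2-(dimethylamino)ethyl, (1-methylpyrrolidin-2-yl)methyl and 1-methylpiperidin-3-yl all stand within the scatter of one another at this place, and none of the three compounds can be set apart from the others. Nothing shown gives a reason for this lack of separation among the three groups.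

As far as these compounds go, all three groups carry a tertiary amine, so it remains open whether a group with no ring or chain nitrogen, such as cyclohexyl, or one with a different ring heteroatom, such as a morpholine ring or a carboxylic acid on a short chain, would give a step beyond the scatter at this amide-type nitrogen. Also open, from the compounds shown here alone, is whether exchanges elsewhere on the shared core, for example of the benzenesulfonyl group, would move the number in this assay.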